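Halogen for methyl on the outer phenoxy ring

A few compounds are considered here, and "the series" means these few. Any claim that something is new, unique, unknown or untested is made for them only; others in the source may bear on it.

Compound 1, `N[C@@H](COP(=O)(O)OCCCOC(=O)CCc1ccccc1OCc1cccc(Oc2ccccc2)c1)C(=O)O`, gives 19.4%.
Compound 2, `Cc1ccccc1Oc1cccc(COc2ccccc2CCC(=O)OCCCOP(=O)(O)OC[C@H](N)C(=O)O)c1`, gives 20.3%.
Compound 3, `N[C@@H](COP(=O)(O)OCCCOC(=O)CCc1ccccc1OCc1cccc(Oc2ccc(Cl)c(Cl)c2)c1)C(=O)O`, gives 18%.

These three compounds share one core and differ only in the group carried on an oxygen on an aromatic ring. In an assay on cells for agonist activity at probable G-protein coupled receptor 34 (Mus musculus), with a stated time of 1 h (a higher number here means a larger maximal response, a lower number a smaller maximal response), the three numbers lie close together: the step of a number 0.9 percentage points higher from compound 1 to compound 2 (within the scatter), the step of a number 1.4 percentage points lower from compound 1 to compound 3 (within the scatter) and the step of a number 2.3 percentage points lower from compound 2 to compound 3 (within the scatter) are all within the scatter, so compound 2 cannot be set apart from compound 1 or compound 3 on these numbers.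

Compound 4, `N[C@@H](COP(=O)(O)OCCCOC(=O)CCc1ccccc1OCc1cccc(Oc2ccc(I)cc2)c1)C(=O)O`, is not yet measured. It differs from compound 2 in one place: 4-iodophenyl in place of 2-methylphenyl on an oxygen on an aromatic ring. The measured steps that bear on this change are those that alter the same group on the same oxygen, from compound 2 to compound 3 and from compound 1 to compound 3, and both stayed within the scatter even though a 3,4-dichlorophenyl entered in place of a 2-methylphenyl or a phenyl. Nothing seen so far suggests that swapping one substituted phenyl for another moves the maximal response beyond the scatter. For compound 4 the expected step is therefore a number 1.3 percentage points lower from compound 2 to compound 4 (within the scatter), essentially none. The estimate for compound 4 in this assay is 19%, with a range from 12% to 27%.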

Compound 4, largest response reached (Emax), in percent of the reference or control that the assay uses: 19.1%
For compound 4 the middle estimate is 0.1 percentage points below the measured one, and the stated range covers the measured number.
By their numbers in this assay, from the lowest: compounds 3, 4, 1 and 2 (each within the scatter of the next).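

In this assay, the 4-iodophenyl group extends the comparison at this place to a single iodine on the outer ring: the step is a number 1.2 percentage points lower from compound 2 to compound 4 (within the scatter) and the two further steps are a number 1.1 percentage points higher from compound 3 to compound 4 (within the scatter) and a number 0.3 percentage points lower from compound 1 to compound 4 (within the scatter). The four groups on this oxygen on an aromatic ring (phenyl, 2-methylphenyl, 3,4-dichlorophenyl and 4-iodophenyl) therefore cannot be told apart by maximal response, and the compounds give no order among them. Nothing measured here offers an explanation for this flat picture.

On these data alone, every group seen so far at this place is a plain phenyl or one carrying methyl or halogen, so it remains open whether an amine, a carboxylic acid or a nitrile on that ring would take the response beyond the scatter. As far as these compounds go, it is equally open what an alkyl chain in place of the whole phenyl would do, and whether any change at this place matters more than a change elsewhere on the shared core.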